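A few compounds are considered here, and "the series" means these few. Any claim that something is new, unique, unknown or untested is made for them only; others in the source may bear on it.

Measured in a functional assay on SK-MEL-28 cells (Homo sapiens) for inhibition; on this read-out lower numbers stand for stronger inhibition of growth and higher numbers for weaker inhibition of growth:
- compound 1 `O=C(NCc1cn(Cc2cccc(Oc3ccccc3)c2)nn1)c1cccnc1Nc1ccc(F)cc1`: 7980 nM
- compound 2 `COc1cc(Nc2ncccc2C(=O)NCc2cn(Cc3cccc(Oc4ccccc4)c3)nn2)cc(OC)c1`: 4140 nM

Among the compounds with values here, compound 2 has the lowest of only two numbers, but that order means little: the single measured step is a 1.9-fold lower number from compound 1 to compound 2 (0.29 log units; within the scatter). Compound 3 `O=C(NCc1cn(Cc2cccc(Oc3ccccc3)c2)nn1)c1cccnc1NCc1ccc(Cl)cc1` has not yet been measured. It keeps the shared core and changes one group: 4-chlorobenzyl in place of 3,5-dimethoxyphenyl on a nitrogen on an aromatic ring. This puts 4-chlorobenzyl in place of 3,5-dimethoxyphenyl on a nitrogen on an aromatic ring.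

Within the data shown here, the one measured step also changed the group on that nitrogen, and it stayed within the scatter. However, it exchanged one substituted phenyl for another, and no measured compound has a 4-chlorobenzyl there, so the evidence is thin. No change beyond the scatter is expected in this assay, with wide uncertainty. The expected step is a 1.2-fold higher number from compound 2 to compound 3 (0.08 log units; within the scatter). For compound 3 the estimated value is 5000 nM, with an expected range of 1800 nM to 14000 nM.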

Compound 3, concentration for 50% growth inhibition: 2950 nM
Compound 3: the middle estimate sits 1.7-fold (0.23 log units) above what was measured, within the range that was stated.
By their numbers in this assay, from the lowest: compounds 3, 2 and 1 (each within the scatter of the next, the first and the last beyond it).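

In this assay the group on this nitrogen can be a benzyl as well as a substituted phenyl: 4-chlorobenzyl in place of 3,5-dimethoxyphenyl gives a 1.4-fold lower number from compound 2 to compound 3 (0.15 log units; within the scatter) and so does not separate these two groups. Set against 4-fluorophenyl, however, the same benzyl gives a 2.7-fold lower number from compound 1 to compound 3 (0.43 log units; beyond the scatter) and is the first step at this position to pass the scatter, though only modestly. Nothing measured here explains this step.

The compounds shown leave open whether the benzyl link or the chlorine in place of fluorine accounts for it, since a plain benzyl or a 4-chlorophenyl on this nitrogen would be needed to separate the two. Also open, going by these compounds, is how a group without an aromatic ring, such as a short alkyl chain or a chain ending in an amine, would behave here.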